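Dichlorophenyl variant of compound 2

The source may report more compounds than this note shows. Statements on the series, on what has been measured and on what is new or still open speak of the compounds shown alone.

Compound 1 `Cc1cc(F)c(S(C)(=O)=O)cc1C(=O)N=C(N)N` and compound 2 `Cc1cc(-c2ccc(Cl)cc2)c(S(C)(=O)=O)cc1C(=O)N=C(N)N` have both been measured in a functional assay for inhibition of sodium/hydrogen exchanger (Oryctolagus cuniculus); on this read-out lower numbers stand for stronger inhibition and higher numbers for weaker inhibition. Compound 1 gives 44 nM in this assay, and compound 2 gives 45 nM. Compound 2 holds the higher of the two numbers, yet the step of a 1.0-fold higher number from compound 1 to compound 2 (0.01 log units; within the scatter) lies within the scatter, so the two compounds cannot be ordered against each other on these numbers.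

Compound 3 `Cc1cc(-c2cc(Cl)cc(Cl)c2)c(S(C)(=O)=O)cc1C(=O)N=C(N)N` has not yet been measured. Its change from compound 2 is 3,5-dichlorophenyl in place of 4-chlorophenyl on an aromatic carbon. Among the compounds with values here, no measured step exchanges one substituted phenyl for another; the only step on record at this carbon is the one from fluoro to 4-chlorophenyl, a 1.0-fold higher number from compound 1 to compound 2 (0.01 log units; within the scatter), which left the number inside the scatter. That step bears only loosely on adding a second chlorine and changing the substitution pattern of the attached ring, and it gives no direction to lean toward. The expectation for a 1.1-fold higher number from compound 2 to compound 3 (0.05 log units; within the scatter) is therefore no step beyond the scatter. Compound 3 is estimated at 50 nM in this assay, with a range from 18 nM to 140 nM.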

Compound 3, half-maximal inhibitory concentration: 130 nM
For compound 3 the middle estimate is 2.6-fold (0.41 log units) below the measured one; the range from low to high includes it.
By their numbers in this assay, from the lowest: compounds 1 and 2 (each within the scatter of the next); then compound 3.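

In this assay, the aromatic carbon ortho to a methylsulfonyl group proves sensitive to the pattern on the attached ring: 3,5-dichlorophenyl in place of 4-chlorophenyl gives a modest loss (a 2.9-fold higher number from compound 2 to compound 3 (0.46 log units; beyond the scatter)). The same group in place of fluoro gives a step of similar size (a 3.0-fold higher number from compound 1 to compound 3 (0.47 log units; beyond the scatter)), so compound 3 stands apart from compound 1 and compound 2, which could not be told apart on their numbers, and a large aryl group at this carbon is therefore not always neutral in this series. No data here explain the shift in the number.

The step from compound 2 to compound 3 changes both the number of chlorines and where they sit on the ring, so the compounds shown cannot say which of the two matters, or whether the weaker number comes with the second chlorine alone. Also open, from the compounds shown here alone, is how this carbon responds to an unsubstituted phenyl, or to a phenyl ring bearing a methoxy group, an amine or a carboxylic acid in place of chlorine.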